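Series notes: amide to anilide-type replacement on the carbonyl

The source may hold more compounds than are shown below. What is called first, only, known or untested is meant among the compounds shown, and "the series" means these compounds.

Compound 2 `COc1cc(-c2nn(-c3cccc(NC(=O)c4ccc(Cl)c(C(F)(F)F)c4)c3)cc2-c2ccncc2)ccc1Cl` stands at the high end of the three numbers in hand. In a functional assay on SNB-19 cells (Homo sapiens) for inhibition, read by sulforhodamine B assay, with a stated time of 48 h (a lower number here means a stronger inhibitor of growth, a higher number a weaker inhibitor of growth), compound 2 gives 8680 nM, the highest of the set and beyond the scatter from both neighbours. Among the measured compounds shown here, compound 1 `O=C(Nc1cccc(-n2cc(-c3ccncc3)c(-c3ccc(Cl)c(O)c3)n2)c1)Nc1ccc(Cl)c(Cl)c1` gives 1460 nM in this assay, and compound 3 `O=C(Nc1cccc(-n2cc(-c3ccncc3)c(-c3ccc(Cl)c(O)c3)n2)c1)Nc1cc(C(F)(F)F)cc(C(F)(F)F)c1` gives 983 nM; no single-change step links either of them to compound 2, so only the values themselves are read: both sit well below compound 2.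

Compound 4 `COc1cc(-c2nn(-c3cccc(NC(=O)Nc4cccc(C(F)(F)F)c4)c3)cc2-c2ccncc2)ccc1Cl` is the next entry, not yet measured. It differs from compound 2 by (3-(trifluoromethyl)phenyl)amino in place of 4-chloro-3-(trifluoromethyl)phenyl on a carbonyl carbon. The change sits on a carbonyl carbon whose other neighbour is an amide-type nitrogen, so the carbonyl in compound 4 carries an amino group on each side.

For the measured compounds named here, no measured step of this kind exists in the set. A move to a lower number is expected, since the two compounds whose carbonyl carries an amino neighbour, compound 1 at 1460 nM and compound 3 at 983 nM, both lie far below compound 2; the expected step is a 3.5-fold lower number from compound 2 to compound 4 (0.54 log units; beyond the scatter). The estimate for compound 4 in this assay is 2500 nM, with a range from 800 nM to 8000 nM.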

Compound 4, concentration for 50% growth inhibition: 981 nM
Beside the measured number, compound 4's estimate is 2.5-fold (0.41 log units) above it; the measured number falls inside the stated range.
By their numbers in this assay, from the lowest: compounds 4, 3 and 1 (each within the scatter of the next); then compound 2.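

Series notes: the carbonyl substituent

In this assay the series now has a single-change step at this carbonyl carbon, and it gives an 8.8-fold lower number from compound 2 to compound 4 (0.95 log units; beyond the scatter) on placing (3-(trifluoromethyl)phenyl)amino where 4-chloro-3-(trifluoromethyl)phenyl stood. The earlier compounds shown here offered only separate values with no connecting step, whereas this pair measures the direction of the change directly: the compound whose carbonyl carries an amino group on each side has the lower number, a claim that rests on this one pair alone. No measurement shown here gives a reason for the step.

The step combines two differences, the entry of the amino nitrogen and the loss of the chlorine, and the compounds shown do not separate them, so the share of each remains unknown. A (4-chloro-3-(trifluoromethyl)phenyl)amino group on the same carbonyl would hold the chlorine while keeping the amino nitrogen, and a methylene in place of that nitrogen would test whether the nitrogen itself matters.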